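The source may report more compounds than this note shows. Statements on the series, on what has been measured and on what is new or still open speak of the compounds shown alone.

Measured so far in an assay on HeLa cells for inhibition of Indoleamine 2,3-dioxygenase 1 (Homo sapiens), read by spectrophotometry, with a stated time of 24 h; on this read-out higher numbers stand for an effect only at larger amounts of compound and lower numbers for an effect already at smaller amounts:
compound 1 `Cc1cccc(NNS(=O)(=O)c2ccc(C(=O)NCC(=O)O)cc2)c1` gives 271 nM;
compound 2 `Cc1cccc(NNS(=O)(=O)c2ccc(S(C)(=O)=O)cc2)c1` gives 7850 nM.

Compound 2 stands highest of the two numbers. Among the measured compounds shown here, the single measured step, a 29-fold higher number from compound 1 to compound 2 (1.46 log units; beyond the scatter), shows that exchanging the group at this one position can move the read-out a great deal. Compound 3 `Cc1cccc(NNS(=O)(=O)c2ccc(C#N)cc2)c1` carries cyano in place of methylsulfonyl on an aromatic carbon. For the measured compounds named here, no measured step tests this particular exchange, so the only guide is that the group at this position matters strongly, and the direction is open. On that basis no step beyond the scatter is expected, and compound 3 is estimated at 8000 nM, within 2500 nM to 25000 nM, a step of a 1.0-fold higher number from compound 2 to compound 3 (0.01 log units; within the scatter).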

Compound 3, half-maximal effective concentration: 3400 nM
For compound 3 the middle estimate is 2.4-fold (0.37 log units) above the measured one, and the stated range covers the measured number.
By their numbers in this assay, from the lowest: compound 1; then compound 3; then compound 2.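

Cyano in place of methylsulfonyl lowers the number modestly (a 2.3-fold lower number from compound 2 to compound 3 (0.36 log units; beyond the scatter)), so this position also responds to a smaller exchange, not only to a large one. The (carboxymethyl)carbamoyl group of compound 1 still stands well apart from cyano (a 13-fold higher number from compound 1 to compound 3 (1.10 log units; beyond the scatter)), which makes the exchange between cyano and methylsulfonyl the lesser of the changes seen here. No measurement shown explains either step.

On these data alone, it remains open which part of the (carboxymethyl)carbamoyl group matters. A plain carboxylic acid, a simple primary amide or a longer chain ending in a carboxylic acid at this position could separate those parts.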